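Series notes: heptyl in place of phenyl

The source may report more compounds than this note shows. Statements on the series, on what has been measured and on what is new or still open speak of the compounds shown alone.

Compound 1 `CC(C)(C)C(=O)c1coc(C(=O)CCCCCCc2ccccc2)n1` and compound 2 `O=C(CCCCc1ccccc1)c1nc2ncccc2o1` both carry a ketone-linked chain on their core. In an assay on HEK-293T cells for inhibition of diacylglycerol lipase-alpha (Homo sapiens), read by colorimetric assay (on this read-out lower numbers stand for stronger inhibition and higher numbers for weaker inhibition), compound 1 gives 479 nM and compound 2 gives 204 nM; compound 2 holds the lower of the two numbers, and its gap to compound 1 lies beyond the scatter. Compound 3 `CCCCCCCCCCCC(=O)c1nc2ncccc2o1` differs from compound 2 by heptyl in place of phenyl on a saturated chain carbon, four bonds along the chain from a carbonyl carbon. Among the compounds with values here, no measured pair shows this change, so its size is unknown; a modest step is expected in this assay, in either direction, possibly none beyond the scatter. Compound 3 is expected at 250 nM (range 80 nM to 800 nM), which would mean a step of a 1.2-fold higher number from compound 2 to compound 3 (0.09 log units; within the scatter).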

Compound 3, half-maximal inhibitory concentration: 30.9 nM
Compound 3: the middle estimate sits 8.1-fold (0.91 log units) above what was measured; the whole stated range lies above it.
By their numbers in this assay, from the lowest: compound 3; then compound 2; then compound 1.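

In this assay heptyl in place of phenyl on a saturated chain carbon, four bonds along the chain from a carbonyl carbon, brings a 6.6-fold lower number from compound 2 to compound 3 (0.82 log units; beyond the scatter) on the shared core. The phenyl ring is therefore not required at this position, and an open chain with no ring gives the stronger inhibition here. Nothing in hand explains the size of this step.

From the compounds shown here alone, whether a longer chain, a shorter chain or a chain ending in a carboxylic acid would do better at this place remains open. Also open, going by these compounds, is whether the same change would carry over to the core of compound 1.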